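The compounds below may be only part of what the source reports. "The series", "measured", "known", "first", "only" and "open" are said of these compounds alone.

Measured so far:
compound 1 `Cc1c(C(=O)NCc2cccc(C(F)(F)F)c2)cnn1-c1ccc(Cl)cc1` — 600 nM
compound 2 `Cc1c(C(=O)NCc2cccc(C(F)(F)F)c2)cnn1-c1cccc(Cl)c1` — > 3000 nM

In a functional assay on cells for antagonist activity at C-C chemokine receptor type 1 (Homo sapiens), read by FLIPR and calcium flux (a lower number here means a stronger inhibitor, a higher number a weaker inhibitor), compound 1 gives 600 nM. For compound 2 this assay reports only a limit, > 3000 nM. Within the data shown here, compound 1 therefore holds the only real number among the two values shown, the other being (the limit of > 3000 nM in this assay, at which 1 of the 2 values shown sits). Among the measured compounds shown here, the single measured step is an at least 5.0-fold higher number from compound 1 to compound 2 (0.69 log units; beyond the scatter), so exchanging the 4-chlorophenyl for a 3-chlorophenyl clearly costs potency.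

Compound 3 `Cc1c(C(=O)NCc2cccc(C(F)(F)F)c2)cnn1-c1cccc(C(F)(F)F)c1` differs from compound 1 by 3-(trifluoromethyl)phenyl in place of 4-chlorophenyl on an aromatic nitrogen. For the measured compounds named here, this change resembles the measured step in that the substituent again sits in the 3-position of the phenyl ring, while the chlorine is swapped for a trifluoromethyl group, for which no measured step exists. Going by the values given here, the step from compound 1 to compound 2 is the only guide, and it points downward beyond the scatter.

Compound 3 is therefore expected to be a weaker inhibitor than compound 1, an estimated 5.0-fold higher number from compound 1 to compound 3 (0.70 log units; beyond the scatter), giving an expected value of 3000 nM (range 1000 nM to 10000 nM), and this assay may well return only a limit for compound 3.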

Compound 3, half-maximal inhibitory concentration: > 3000 nM
Compound 3 gave a limit, no number (the forecaster's own chance of this, stated with the estimate: 55%); the middle value lies on the limit itself.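

Placing 3-(trifluoromethyl)phenyl instead of 4-chlorophenyl on the aromatic nitrogen gives, in this assay, an at least 5.0-fold higher number from compound 1 to compound 3 (0.69 log units; beyond the scatter). The loss seen with 3-chlorophenyl is therefore not confined to a chloro substituent: two different groups, 3-chlorophenyl and 3-(trifluoromethyl)phenyl, both fall short of the 4-chlorophenyl of compound 1, and none of the three compounds goes against this. How much potency each of these changes really costs cannot be read, and neither can the step between compound 2 and compound 3, so chloro and trifluoromethyl cannot be ranked against each other here: the limit of > 3000 nM in this assay, at which 2 of the 3 values shown sit.

The compounds shown leave open whether the drop follows the place of the substituent on the phenyl ring or simply the move away from 4-chlorophenyl, as trifluoromethyl appears here only in the 3-(trifluoromethyl)phenyl group. A 4-(trifluoromethyl)phenyl group would test whether trifluoromethyl can stand where the chlorine of compound 1 sits, and a 4-methoxyphenyl or 4-aminophenyl group would show whether anything other than a halogen can serve there.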